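This account rests on a few compounds, and the source may have more. Where it says the series, first, only, none or still open, it means among the compounds named here.

The measured compounds:
compound 1, `O=c1[nH]cc(S(=O)(=O)Nc2cccc(-c3cn(-c4ccc(F)cc4)nn3)c2)c(=O)[nH]1`: > 20000 nM
compound 2, `O=c1[nH]cc(S(=O)(=O)Nc2cccc(-c3cn(-c4ccccc4Cl)nn3)c2)c(=O)[nH]1`: 2730 nM

In a functional assay on A549 cells (Homo sapiens) for antiproliferative activity, read by MTT assay, with a stated time of 24 h (a higher number here means a weaker inhibitor, a lower number a stronger inhibitor), compound 1 gives > 20000 nM, which is a limit of the assay and not a number. Going by the values given here, compound 2 gives 2730 nM in this assay, the only actual number in the set. The step of an at least 7.3-fold lower number from compound 1 to compound 2 (0.86 log units; beyond the scatter) therefore rests on (the limit of > 20000 nM in this assay, at which 1 of the 2 values shown sits), so its true size is known only as a lower bound.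

Compound 3, `O=c1[nH]cc(S(=O)(=O)Nc2cccc(-c3cn(-c4cccc(Cl)c4)nn3)c2)c(=O)[nH]1`, has not yet been measured. It differs from compound 2 by 3-chlorophenyl in place of 2-chlorophenyl on an aromatic nitrogen. Among the compounds with values here, the only measured step that bears on this change is the one that swaps the aryl group on the same aromatic nitrogen, an at least 7.3-fold lower number from compound 1 to compound 2 (0.86 log units; beyond the scatter), and it shows that the choice of that aryl group can move the result by far more than the scatter. It gives no direct reading of the 3-chlorophenyl, so the direction for compound 3 is open, with a real chance of a weaker result. Compound 3 is estimated at 5500 nM, within 1500 nM to 20000 nM, an expected step of a 2.0-fold higher number from compound 2 to compound 3 (0.30 log units; within the scatter).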

Compound 3, half-maximal inhibitory concentration: 2430 nM
Compound 3: middle estimate off by 2.3-fold (0.35 log units), on the high side; measured number inside the range.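

In this assay, 3-chlorophenyl in place of 2-chlorophenyl on the aromatic nitrogen gives a 1.1-fold lower number from compound 2 to compound 3 (0.05 log units; within the scatter), so compound 2 and compound 3 cannot be told apart and this shift of the chlorine makes no measurable difference here. Going by these compounds alone, the earlier compounds showed only that the aryl group on this nitrogen can matter, whereas the second chlorophenyl group now gives a step from the 4-fluorophenyl compound that is also beyond the scatter, an at least 8.2-fold lower number from compound 1 to compound 3 (0.91 log units; beyond the scatter). The true size of that step is known only as a lower bound, as it too rests on a limit of the assay and not a number: the limit of > 20000 nM in this assay, at which 1 of the 3 values shown sits.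

The compounds shown leave open whether the gap to compound 1 follows the kind of halogen or its place on the phenyl group, as 4-fluorophenyl differs from both chlorophenyl groups in both respects. Going by these compounds, how 4-chlorophenyl would read on this nitrogen, which would separate the two, remains unknown, as does the reading of an unsubstituted phenyl or of a phenyl carrying a methoxy group or an amine.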